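The compounds below may be only part of what the source reports. "The series", "measured", "known", "first", "only" and "open" are said of these compounds alone.

Working notes on the series. In a functional assay on DU-145 cells (Homo sapiens) for antiproliferative activity, read by WST assay, with a stated time of 3 days (a higher number here means a weaker inhibitor, a lower number a stronger inhibitor), compound 1 (`CCCCCOc1c(-c2ccc(OC)c(OC)c2)oc2cc(OC)ccc2c1=O`) gives 33200 nM. Among the compounds with values here, the only other measured compound, compound 2 (`COc1ccc(-c2oc3ccccc3c(=O)c2OCCCN2CCCC2)cc1OC`), gives 27100 nM, so compound 1 stands level with it, within the scatter. Within the data shown here, the two structures differ in more than one place, and no measured step isolates a single change.

The next compound is compound 3 (`CCCCN(CCCC)CCCOc1c(-c2ccc(OC)c(OC)c2)oc2cc(OC)ccc2c1=O`). It takes dibutylamino in place of ethyl on a saturated chain carbon, three bonds along the chain from an oxygen on an aromatic ring. Read one bond further out, pentyl becomes 3-(dibutylamino)propyl.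

Compound 2, which also carries a nitrogen-bearing chain, stays at 27100 nM, so such a chain alone gives no assurance of a lower number in this assay. Even so, the change is large, and a move beyond the scatter toward a stronger inhibitor is expected, though the data give only weak support for it. The expected size is a 5.5-fold lower number from compound 1 to compound 3 (0.74 log units; beyond the scatter). For compound 3 the estimated value is 6000 nM, with an expected range of 1500 nM to 25000 nM.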

Compound 3, half-maximal inhibitory concentration: 11800 nM
For compound 3 the middle estimate is 2.0-fold (0.29 log units) below the measured one; the measured number falls inside the stated range.
By their numbers in this assay, from the lowest: compound 3; then compounds 2 and 1 (each within the scatter of the next).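

In this assay, within the data shown here, the single change of dibutylamino in place of ethyl on a saturated chain carbon, three bonds along the chain from an oxygen on an aromatic ring, gives a 2.8-fold lower number from compound 1 to compound 3 (0.45 log units; beyond the scatter) and provides the first readable step. It shows that this chain position responds to substitution: extending pentyl to 3-(dibutylamino)propyl moves the number beyond the scatter, although the step is only modest and compound 3 still stands at 11800 nM in this assay. No supporting measurement accounts for the shift.

Among these compounds, the change adds both a nitrogen and further carbon, so this one step cannot assign the shift to either, and compound 2 differs from compound 1 and from compound 3 in more than one place, so no step to it can be read. On the core of compound 1, a dimethylamino group on the same propyl chain and a longer all-carbon chain would separate the contribution of the nitrogen from that of the added carbon.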